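This account rests on a few compounds, and the source may have more. Where it says the series, first, only, none or still open, it means among the compounds named here.

In a physicochemical assay for acid dissociation, compound 1 `COc1ccc(-c2c(C)nc3c(NCc4ccc(C(N)=O)cc4)cc(C)cn23)cc1OC` gives 6.6 and compound 2 `COc1ccc(-c2c(C)nc3c(NCc4cccnc4)cc(C)cn23)cc1OC` gives 6.5. Compound 3 `COc1ccc(-c2c(C)nc3c(NCc4ccc(C(N)=O)cc4)nc(C)cn23)cc1OC` gives 5, the lowest of the three numbers and clearly apart from both others. The next structure, compound 4 `COc1ccc(-c2c(C)nc3c(NCC4CCOCC4)nc(C)cn23)cc1OC`, follows from compound 3 by one change: oxan-4-yl in place of 4-carbamoylphenyl on a saturated chain carbon bound to a nitrogen on an aromatic ring. Here oxan-4-yl stands in place of 4-carbamoylphenyl on a saturated chain carbon bound to a nitrogen on an aromatic ring.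

For the measured compounds named here, one measured step bears on this place: a number 0.10 log units lower from compound 1 to compound 2 (within the scatter). That step removes the same 4-carbamoylphenyl but brings in pyridin-3-yl, and it was measured on the core of compound 1, not that of compound 3. Going by the values given here, no measured compound carries oxan-4-yl, so the guide is indirect. Going by that single small step, no change beyond the scatter is expected in this assay. The expected change is a number 0.20 log units higher from compound 3 to compound 4 (within the scatter). The estimate for compound 4 is 5.2, with an expected range from 4.8 to 5.6.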

Compound 4, acid dissociation constant: 5.6
Compound 4: middle estimate off by 0.40 log units, on the low side, within the range that was stated.
By their numbers in this assay, from the lowest: compound 3; then compound 4; then compounds 2 and 1 (each within the scatter of the next).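

In this assay, for the compounds shown here, the change at this place reads a number 0.60 log units higher from compound 3 to compound 4 (beyond the scatter) and so lies beyond the scatter, whereas the only earlier step at this place, a number 0.10 log units lower from compound 1 to compound 2 (within the scatter) on the core of compound 1, did not. Both 4-carbamoylphenyl and pyridin-3-yl are aromatic, so this is the first step shown in which a six-membered non-aromatic ring with 1 hetero atom, oxan-4-yl, enters on a saturated chain carbon bound to a nitrogen on an aromatic ring.

The compounds shown leave open whether oxan-4-yl would move the number in the same way on the core of compound 1. They also leave open whether cyclohexyl, which lacks the ring oxygen, or piperidin-4-yl, which carries a ring amine instead, would give a similar number on the core of compound 3. No evidence at hand accounts for the size of this step.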